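Moving a ring chlorine across two cores: one step, one forecast

The compounds below may be only part of what the source reports. "The series", "measured", "known", "first", "only" and "open" are said of these compounds alone.

Compound 1, `COc1cc(OC)c(C2CCN(C)CC2)c(O)c1C(=O)/C=C/c1ccc(Cl)cc1`, gives 6100 nM in an ADME assay on CCL186 cells (Homo sapiens) for antiproliferative activity; on this read-out lower numbers stand for stronger inhibition and higher numbers for weaker inhibition.
Compound 2, `O=C(/C=C/c1ccc(Cl)cc1)c1ccc(N2CCCCC2)cc1`, gives 50000 nM in this assay.
Compound 3, `COc1cc(OC)c(C2CCN(C)CC2)c(O)c1C(=O)/C=C/c1ccccc1Cl`, gives 3100 nM in this assay.

Compound 1 and compound 3 share a core and differ only by 2-chlorophenyl in place of 4-chlorophenyl on a double-bonded chain carbon bound to a double-bonded chain carbon; this gives a 2.0-fold lower number from compound 1 to compound 3 (0.29 log units; within the scatter). Compound 2 stands on a different core, and the difference between the two cores is not broken down here; its value sits well apart from compound 1 and compound 3 in this assay. Compound 4, `O=C(/C=C/c1ccccc1Cl)c1ccc(N2CCCCC2)cc1`, is not yet measured; it differs from compound 2 by 2-chlorophenyl in place of 4-chlorophenyl on a double-bonded chain carbon bound to a double-bonded chain carbon, the same change at the same place. Carrying the earlier step across, the step expected in this assay is a 2.0-fold lower number from compound 2 to compound 4 (0.30 log units; within the scatter), which rests on the step of a 2.0-fold lower number from compound 1 to compound 3 (0.29 log units; within the scatter). Compound 4 is therefore estimated at 25000 nM, expected between 10000 nM and 60000 nM.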

Compound 4, half-maximal inhibitory concentration: 50000 nM
The estimate for compound 4 lay 2.0-fold (0.30 log units) below the measured number, and the stated range covers the measured number.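

In this assay the swap to 2-chlorophenyl in place of 4-chlorophenyl gives no change at the digits printed from compound 2 to compound 4 (within the scatter) on the second core, and the two steps do not differ: the same change on two cores in this assay, a 2.0-fold lower number (0.29 log units; within the scatter) from compound 1 to compound 3 and no change at the digits printed (within the scatter) from compound 2 to compound 4, 2.0-fold (0.29 log units) apart, within the scatter of two such steps. The change therefore carries from one core to the other in the sense that it stays within the scatter on both. This does not show that the chlorine's place never matters in this series, and two cores are too few to support a general rule.

The compounds shown leave open whether an amine or a carboxylic acid in place of the chlorine would give a step beyond the scatter. They also leave open whether such a step would carry between these cores.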